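This account rests on a few compounds, and the source may have more. Where it says the series, first, only, none or still open, it means among the compounds named here.

Measured in a functional assay on CCRF-CEM cells (Homo sapiens); a higher number here means a weaker inhibitor, a lower number a stronger inhibitor:
- compound 1 `Cn1ncc2c1[C@@H](CO[Si](c1ccccc1)(c1ccccc1)C(C)(C)C)C[C@H]2Cn1cnc2c(O)ncnc21`: 3.2 ug/mL
- compound 2 `CCOc1ncnc2c1ncn2C[C@@H]1C[C@H](CO)c2ccccc21`: 24 ug/mL
- compound 3 `Cn1ncc2c1[C@H](Cn1cnc3c(Cl)nc(N)nc31)C[C@@H]2CO`: 3.2 ug/mL

Compound 2, at 24 ug/mL, stands highest of the three and is the weakest inhibitor here, with its gaps to compound 1 and compound 3 both beyond the scatter. The next compound for this assay is compound 4 `OC[C@H]1C[C@@H](Cn2cnc3c(O)ncnc32)c2ccccc21`, which differs from compound 2 by hydrogen in place of ethyl on an oxygen on an aromatic ring. Going by the values given here, no measured pair isolates this change, so the size of the step remains open. Compound 1 also carries a hydroxy group on an aromatic ring and gives 3.2 ug/mL, but it differs from compound 4 elsewhere too, so it offers only weak support for a move to a lower number. No change beyond the scatter is therefore expected, and the estimated step is a 1.6-fold lower number from compound 2 to compound 4 (0.20 log units; within the scatter). For compound 4 the expected value is 15 ug/mL, with an estimated range of 4 ug/mL to 60 ug/mL.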

Compound 4, half-maximal inhibitory concentration: 24 ug/mL
For compound 4 the middle estimate is 1.6-fold (0.20 log units) below the measured one; the range from low to high includes it.
By their numbers in this assay, from the lowest: compounds 1 and 3 (each within the scatter of the next); then compounds 2 and 4 (each within the scatter of the next).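

In this assay, going by these compounds alone, the change from ethoxy to hydroxy on an oxygen on an aromatic ring gives no change at the digits printed from compound 2 to compound 4 (within the scatter), the first measured pair that isolates this position. On this core, the ethyl group can therefore be replaced by hydrogen without a change in the number beyond the scatter, so the hydroxy group alone does not lower it here. No measurement on hand offers an explanation for this flat step.

From the compounds shown here alone, whether a longer chain such as butyl on this oxygen, or an amine in its place, would also leave the number unchanged remains open. This single pair also does not show whether the same change would behave alike on the core of compound 1 or compound 3.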